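Urea to Amide Swap on the Shared Core

This account rests on a few compounds, and the source may have more. Where it says the series, first, only, none or still open, it means among the compounds named here.

Compound 2 `COc1cc(Cl)cc(-c2nn(-c3cccc(NC(=O)Nc4ccc(Cl)c(Cl)c4)c3)cc2-c2ccncc2)c1` gives 87% in a functional assay on SN12C cells (Homo sapiens) for inhibition, read by sulforhodamine B assay, with a stated time of 48 h, tested at 1 uM (a lower number here means a stronger effect, a higher number a weaker effect of the compound at the concentration tested), the highest of the two numbers shown. Compound 1 `O=C(Nc1cccc(-n2cc(-c3ccncc3)c(-c3cc(O)cc(Cl)c3)n2)c1)Nc1ccc(Cl)c(Cl)c1` gives 58% in this assay, and the step of a number 29 percentage points higher from compound 1 to compound 2 (beyond the scatter) follows from methyl in place of hydrogen on an oxygen on an aromatic ring. Compound 3 `COc1cc(Cl)cc(-c2nn(-c3cccc(NC(=O)c4cccc(C(F)(F)F)c4)c3)cc2-c2ccncc2)c1` differs from compound 2 by 3-(trifluoromethyl)phenyl in place of (3,4-dichlorophenyl)amino on a carbonyl carbon. No measured step touches the carbonyl carbon, so the single step shown does not bear on this change, and no shift beyond the scatter is expected. Compound 3 is estimated at 85%, within 55% to 100%, an expected step of a number 2 percentage points lower from compound 2 to compound 3 (within the scatter).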

Compound 3, a percentage reported as activity, at one concentration (the size of the read-out at that concentration, not a potency): 58%
Compound 3: the middle estimate sits 27 percentage points above what was measured; low and high end bracket the measured number.
By their numbers in this assay, from the lowest: compounds 1 and 3 (each within the scatter of the next); then compound 2.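

In this assay, 3-(trifluoromethyl)phenyl in place of (3,4-dichlorophenyl)amino on a carbonyl carbon gives a number 29 percentage points lower from compound 2 to compound 3 (beyond the scatter), a stronger effect at the concentration tested. Within the data shown here, the earlier step concerned only the methyl on an oxygen, so this is the first sign that the group on the carbonyl carbon also moves the read-out. No measurement shown accounts for this shift.

The change replaces the amino nitrogen and alters the ring substituents together, and the compounds shown do not separate the two, as a 3,4-dichlorophenyl directly on the carbonyl carbon could. Going by these compounds, how the amide form behaves with a hydroxyl in place of the methoxy group also remains open.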